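The source may report more compounds than this note shows. Statements on the series, on what has been measured and on what is new or still open speak of the compounds shown alone.

Compound 1 `COC(=O)Cn1n[n+]([O-])c2cc(C)c(C)cc21` was tested in a functional assay on HeLa cells (Homo sapiens) for inhibition, read by colorimetric assay, with a stated time of 72 h; on this read-out lower numbers stand for an effect already at smaller amounts and higher numbers for an effect only at larger amounts of compound. In this assay compound 1 gives only a limit, > 100 ug/mL, and not a number. Its place among the values shown is therefore the upper edge, (the limit of > 100 ug/mL in this assay, at which 1 of the 2 values shown sits). Compound 2 `COC(=O)Cn1nc2c(n1)C(=O)C(C)=C(C)C2=O`, which carries a different core, gives 1 ug/mL in this assay, a value well within the measured range.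

Compound 3 `Cc1cc2c(cc1C)[n+]([O-])nn2C` has not yet been measured. It differs from compound 1 in one place: hydrogen in place of methoxycarbonyl on a saturated chain carbon bound to an aromatic nitrogen. The change removes the methoxycarbonyl group from the saturated chain carbon bound to an aromatic nitrogen and leaves a methyl in its place, while the core of compound 1 is kept unchanged. Among the compounds with values here, since only a limit is known for compound 1, no measured step in this assay can guide the expectation. Compound 3 is expected to stay at about the same level, with a step that the limit leaves unreadable from compound 1 to compound 3 that is estimated to be none beyond the scatter. For compound 3 the estimated value is 150 ug/mL, within a range from 50 ug/mL to 500 ug/mL.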

Compound 3, concentration for half-maximal effect: > 100 ug/mL
Compound 3: no number, only a limit (the forecaster's own chance of this, stated with the estimate: 80%); the middle value lies beyond the limit too.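

Within the data shown here, compound 1 and compound 3 each give only a limit in this assay and not a number, so no step between them can be read. The compounds shown leave open how far either lies beyond that limit, and whether leaving out the methoxycarbonyl changes the effect at all.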